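Swapping Methoxycarbonyl for Trifluoromethyl: An Expected Solubility Shift

The compounds below may be only part of what the source reports. "The series", "measured", "known", "first", "only" and "open" are said of these compounds alone.

Measured compounds:
Compound 1, `COC(=O)c1ccc(NC(=O)Nc2cc(C)nc3ccccc23)cc1`: 1200 nM
Compound 2, `Cc1cc(NC(=O)Nc2ccc(C(F)(F)F)cc2)c2ccccc2n1`: 100 nM
Compound 3, `COC(=O)c1cccc(NC(=O)Nc2cc(C)nc3ccccc23)c1`: 600 nM

In a physicochemical assay for solubility, at pH 7.4 (a lower number here means a less soluble compound, a higher number a more soluble compound), compound 1 gives 1200 nM. In the same assay compound 2 gives 100 nM, and compound 3 gives 600 nM. Compound 1 and compound 2 differ in a single place: trifluoromethyl in place of methoxycarbonyl on an aromatic carbon This change made a step of a 12-fold lower number from compound 1 to compound 2 (1.08 log units; beyond the scatter).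

Compound 3 is built from the same atoms as compound 1, joined differently; the difference between the two cores is not broken down here. The two values of compound 1 and compound 3 lie within the usual scatter of each other, so nothing can be said about an order between them.

Compound 4, `Cc1cc(NC(=O)Nc2cccc(C(F)(F)F)c2)c2ccccc2n1`, has not yet been measured. Within the data shown here, it differs from compound 3 in one place: trifluoromethyl in place of methoxycarbonyl on an aromatic carbon This is the same kind of change as the one from compound 1 to compound 2, but not the same: in compound 2 the entering group sits para to a large group, whereas in compound 4 it sits meta to a large group.

Resting on the step of a 12-fold lower number from compound 1 to compound 2 (1.08 log units; beyond the scatter), the step from compound 3 to compound 4 in this assay is expected to be a 10-fold lower number from compound 3 to compound 4 (1.00 log units; beyond the scatter), placed beside the earlier one. Compound 4 is therefore estimated at 60 nM. The estimate for compound 4 is expected to lie between 20 nM and 200 nM.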

Compound 4, solubility: 100 nM
Compound 4: middle estimate off by 1.7-fold (0.22 log units), on the low side, and the stated range covers the measured number.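

In this assay, replacing methoxycarbonyl with trifluoromethyl on an aromatic carbon gives a 6.0-fold lower number from compound 3 to compound 4 (0.78 log units; beyond the scatter) in the new core, and the same kind of change gives a 12-fold lower number from compound 1 to compound 2 (1.08 log units; beyond the scatter) in the earlier one, so both steps run in the same direction and both lie beyond the usual scatter. This shows that the direction of the step carried over between these two related cores, the parts of the molecules left unchanged by the swap, but two pairs are a small sample and cannot show that it would carry over to any other core. Nothing shown here bears on why the number falls with this swap, so the two steps record an outcome and not its cause.

The compounds shown leave open what number a carboxylic acid, an amine or a nitrile would give on the same aromatic carbon in this assay and whether any of these would follow the trifluoromethyl compounds or part from them. They also leave open whether a longer chain, such as an ethyl ester in place of the methoxycarbonyl, would start from a similar number on either core.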